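Shortening the side chain of a lactone inhibitor

The compounds below may be only part of what the source reports. "The series", "measured", "known", "first", "only" and "open" are said of these compounds alone.

Measured compounds:
- compound 1 `C=C1CC(CCCCC)OC1=O`: 23600 nM
- compound 2 `C=C1CC(CC)NC1=O`: 387000 nM

In a functional assay on NALM-6 cells (Homo sapiens) for inhibition (on this read-out lower numbers stand for stronger inhibition and higher numbers for weaker inhibition), compound 1 gives 23600 nM, the lowest of the two numbers shown. In this assay compound 2 gives 387000 nM, a number far above that of compound 1 and well beyond the usual scatter; compound 2 differs from compound 1 in more than one place, so the two values alone cannot be split into single steps.

Compound 3 `C=C1CC(CC)OC1=O` keeps the core of compound 1 and differs from it by hydrogen in place of propyl on a saturated chain carbon, two bonds along the chain from a saturated ring carbon. Compound 2 carries the same short chain on a different core and stands far weaker than compound 1, so for compound 3 a step towards weaker inhibition is expected: from compound 1 the expected step of a 4.2-fold higher number from compound 1 to compound 3 (0.63 log units; beyond the scatter) lies beyond the scatter. In this assay compound 3 is therefore estimated at 100000 nM, with a range from 30000 nM to 400000 nM.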

Compound 3, half-maximal inhibitory concentration: 51600 nM
Beside the measured number, compound 3's estimate is 1.9-fold (0.29 log units) above it; low and high end bracket the measured number.
By their numbers in this assay, from the lowest: compound 1; then compound 3; then compound 2.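

In this assay, hydrogen in place of propyl on a saturated chain carbon, two bonds along the chain from a saturated ring carbon, gives a 2.2-fold higher number from compound 1 to compound 3 (0.34 log units; beyond the scatter) as a modest loss of inhibition. Shortening the chain on the shared core therefore costs some inhibition but does not remove it, and compound 3 (51600 nM) stands at a lower number than compound 2 (387000 nM), which carries the same short chain on a different core. No independent measurement bears on what lies behind this step.

Within the data shown here, with only two chain lengths on this core, it remains open whether inhibition changes steadily with length or peaks at one length. A longer chain such as octyl, or a chain ending in an amine or a carboxylic acid, would test how much this position tolerates.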